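The source may hold more compounds than are shown below. What is called first, only, known or untested is meant among the compounds shown, and "the series" means these compounds.

Compound 1 `Nc1ccc(COc2ccc(OCCOCCNC3CCCC3)cc2)cc1` gives 31700 nM in a functional assay on SK-OV-3 cells (Homo sapiens) for inhibition, read by CCK-8 assay, with a stated time of 70 h (on this read-out lower numbers stand for stronger inhibition and higher numbers for weaker inhibition), the highest of the three numbers at hand. Compound 2 `c1ccc(COc2ccc(OCCOCCNC3CCC3)cc2)cc1` gives 25000 nM in this assay, within the scatter of compound 1, while compound 3 `c1ccc(COc2ccc(COc3ccc(OCCOCCNC4CCCC4)cc3)cc2)cc1` gives 10000 nM, the step of a 3.2-fold lower number from compound 1 to compound 3 (0.50 log units; beyond the scatter) lying beyond the scatter. Compound 4 `COC(=O)c1cccc(COc2ccc(OCCOCCNC3CCCC3)cc2)c1` differs from compound 1 by 3-(methoxycarbonyl)phenyl in place of 4-aminophenyl on a saturated chain carbon bound to an oxygen on an aromatic ring. Among the measured compounds shown here, the one measured step that bears on this change is a 3.2-fold lower number from compound 1 to compound 3 (0.50 log units; beyond the scatter), where replacing the amino with benzyloxy was followed by a modest lowering. A step of similar size is expected for compound 4, namely a modest lowering a 2.1-fold lower number from compound 1 to compound 4 (0.32 log units; beyond the scatter). Compound 4 is therefore estimated at 15000 nM in this assay, with a range from 6000 nM to 40000 nM.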

Compound 4, half-maximal inhibitory concentration: 45500 nM
Estimate against measurement, compound 4: 3.0-fold (0.48 log units) below; the measured number lies above the stated range.
By their numbers in this assay, from the lowest: compound 3; then compounds 2, 1 and 4 (each within the scatter of the next).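

In this assay, the step of a 1.4-fold higher number from compound 1 to compound 4 (0.16 log units; within the scatter) stays within the scatter, so exchanging 4-aminophenyl for 3-(methoxycarbonyl)phenyl on this saturated chain carbon leaves the number effectively unchanged. By contrast, a 3.2-fold lower number from compound 1 to compound 3 (0.50 log units; beyond the scatter) lies beyond the scatter, so not every change to this aromatic group leaves the number in place. No available evidence accounts for this difference. Still open, going by these compounds, is whether a carboxylic acid or an amide in place of the methoxycarbonyl would shift the number, and whether larger groups resembling benzyloxy would lower it further.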